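Series notes: Caco-2 permeability ahead of compound 4

The source may hold more compounds than are shown below. What is called first, only, known or untested is meant among the compounds shown, and "the series" means these compounds.

Measured so far in an ADME assay on Caco-2 cells (Homo sapiens) for permeability, read by LC-MS, with a stated time of 2 h, tested at 3 uM; on this read-out higher numbers stand for higher permeability and lower numbers for lower permeability:
compound 1 `CCN(c1cc2oc(-c3ccc(F)cc3)c(C(=O)NC)c2cc1-c1cc(F)c(OC)c(C(=O)NC2(c3ncccn3)CC2)c1)S(C)(=O)=O`, 406 nm/s
compound 2 `CCN(c1cc2oc(-c3ccc(F)cc3)c(C(=O)NC)c2cc1-c1cc(F)c(F)c(C(=O)NC2(c3ncccn3)CC2)c1)S(C)(=O)=O`, 623 nm/s
compound 3 `CCN(C(=O)N(C)C)c1cc2oc(-c3ccc(F)cc3)c(C(=O)NC)c2cc1-c1ccc(OC)c(C(=O)NC2(c3ncccn3)CC2)c1`, 479 nm/s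

Compound 3 stands second of the three numbers, but its value and those of compound 1 and compound 2 all lie within the scatter of one another, so no order among them is read. For the measured compounds named here, the one single-point step measured, a 1.5-fold higher number from compound 1 to compound 2 (0.19 log units; within the scatter), concerns an aromatic substituent and does not touch the carbonyl carbon of interest here. Compound 4 `CCN(C(=O)C(F)(F)F)c1cc2oc(-c3ccc(F)cc3)c(C(=O)NC)c2cc1-c1ccc(OC)c(C(=O)NC2(c3ncccn3)CC2)c1` differs from compound 3 by trifluoromethyl in place of dimethylamino on a carbonyl carbon. Going by the values given here, no measured step bears on this change, so the step of a 1.0-fold higher number from compound 3 to compound 4 (0.00 log units; within the scatter) is expected to remain within the scatter, with no direction claimed. Compound 4 is therefore estimated at 480 nm/s, in the range 280 nm/s to 800 nm/s.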

Compound 4, apparent permeability: 115 nm/s
Compound 4: middle estimate off by 4.2-fold (0.62 log units), on the high side; the measured number lies below the stated range.
By their numbers in this assay, from the lowest: compound 4; then compounds 1, 3 and 2 (each within the scatter of the next).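

In this assay, trifluoromethyl in place of dimethylamino on a carbonyl carbon gives a 4.2-fold lower number from compound 3 to compound 4 (0.62 log units; beyond the scatter), the only step among these compounds that lies beyond the scatter. For the compounds shown here, this position therefore registers on this read-out, which the earlier compounds, all within the scatter of one another, did not show. Nothing available accounts for the step. As far as these compounds go, it remains open whether the step follows the loss of dimethylamino or the arrival of trifluoromethyl. A tert-butyl or a pyrrolidine on the same carbonyl carbon would help separate the two.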